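This account rests on a few compounds, and the source may have more. Where it says the series, first, only, none or still open, it means among the compounds named here.

Compound 1 `COc1ccc(Cc2nnc(CN(c3cccc(Cl)c3C)S(=O)(=O)c3ccc(C)cc3)o2)cc1` gives 39.8 nM in a functional assay on CHO cells for antagonist activity at prostaglandin E2 receptor EP1 subtype (Homo sapiens), read by FLIPR and calcium flux; on this read-out lower numbers stand for stronger inhibition and higher numbers for weaker inhibition.
Compound 2 `Cc1ccc(S(=O)(=O)N(Cc2nnc(Cc3ccc(N(C)C)cc3)o2)c2cccc(Cl)c2C)cc1` gives 20 nM.
Compound 3 `Cc1ccc(S(=O)(=O)N(Cc2nnc(Cc3ccc(C(F)(F)F)cc3)o2)c2cccc(Cl)c2C)cc1` gives 158 nM.

Among these three, compound 3 gives the highest number. The step of a 4.0-fold higher number from compound 1 to compound 3 (0.60 log units; beyond the scatter) and the step of a 7.9-fold higher number from compound 2 to compound 3 (0.90 log units; beyond the scatter) both lie beyond the scatter, while the step of a 2.0-fold lower number from compound 1 to compound 2 (0.30 log units; within the scatter) stays within the scatter, so compound 1 and compound 2 cannot be separated on this read-out.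

Compound 4 `Cc1ccc(S(=O)(=O)N(Cc2nnc(Cc3ccccc3F)o2)c2cccc(Cl)c2C)cc1` has not been measured. It differs from compound 3 in one place: 2-fluorophenyl in place of 4-(trifluoromethyl)phenyl on a saturated chain carbon bound to an aromatic carbon. The measured steps all exchange one group for another at a single place on that ring; none of them removes the group from that place or carries a fluorine to a different point on the ring. Within the data shown here, what the series does show is that trifluoromethyl marks the weak end of the three, so leaving it behind has room to lower the number, but the entering group has no measured counterpart. The expectation for compound 4 in this assay is therefore a moderate drop, a 2.0-fold lower number from compound 3 to compound 4 (0.30 log units; within the scatter), held with wide bounds. Compound 4 is estimated at 80 nM, ranging from 25 nM to 250 nM.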

Compound 4, inhibition constant: 631 nM
The estimate for compound 4 lay 7.9-fold (0.90 log units) below the measured number; measured number outside the range, above it.
By their numbers in this assay, from the lowest: compounds 2 and 1 (each within the scatter of the next); then compound 3; then compound 4.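

In this assay, the weak end of this position moves past trifluoromethyl: replacing 4-(trifluoromethyl)phenyl with 2-fluorophenyl gives a 4.0-fold higher number from compound 3 to compound 4 (0.60 log units; beyond the scatter), so the substituted phenyl on this saturated chain carbon can raise the number further than the earlier exchanges showed. The steps of a 32-fold higher number from compound 2 to compound 4 (1.50 log units; beyond the scatter) and a 16-fold higher number from compound 1 to compound 4 (1.20 log units; beyond the scatter) are large, and no exchange among the first three compounds reached that size, so this place can carry a wide spread in the read-out. Nothing available bears on the reason for this rise.

The single exchange both removes a group named at the 4 of the phenyl and brings in a fluorine named at the 2, so these two changes cannot be separated from the four compounds shown. Plain phenyl at this place would help to divide them, and 2-fluorophenyl paired with the 4-methoxy or 4-(dimethylamino) group on the same ring would test whether the fluorine still raises the number when such a group is present.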